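The source may report more compounds than this note shows. Statements on the series, on what has been measured and on what is new or still open speak of the compounds shown alone.

Compound 1 `C=CC(=O)Nc1cccc(NC(=O)CSc2nc(Nc3cccc(Br)c3)c3ccccc3n2)c1`: 11900 nM
Compound 2 `C=CC(=O)Nc1cccc(NC(=O)CSc2nc(Nc3cccc(C)c3)c3ccccc3n2)c1`: 20900 nM

Both were tested in a functional assay on MGC-803 cells (Homo sapiens) for inhibition, read by MTT assay, with a stated time of 72 h; on this read-out higher numbers stand for weaker inhibition and lower numbers for stronger inhibition. Among the compounds with values here, compound 2 shows the higher of the two numbers, yet the only step toward it, a 1.8-fold higher number from compound 1 to compound 2 (0.24 log units; within the scatter), lies within the scatter, so the two values cannot be ranked. Compound 3 `C=CC(=O)Nc1cccc(NC(=O)CSc2nc(Nc3cc(OC)c(OC)c(OC)c3)c3ccccc3n2)c1` has not been tested. Its change from compound 2 is 3,4,5-trimethoxyphenyl in place of 3-methylphenyl on a nitrogen on an aromatic ring. Within the data shown here, no measured step exchanges one whole substituted ring for another, so nothing here bears directly on this change, and the one step seen was small. A step of a 1.2-fold lower number from compound 2 to compound 3 (0.06 log units; within the scatter) is therefore expected, none beyond the scatter. Compound 3 is estimated at 18000 nM, between 6000 nM and 55000 nM.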

Compound 3, half-maximal inhibitory concentration: > 50000 nM
Compound 3: a limit, no number; the forecaster's own chance of this, stated with the estimate: 10%; at least 2.7-fold (0.44 log units) between middle value and limit.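

In this assay, this position proved able to respond: the exchange of bromo for methyl had stayed within the scatter, but 3,4,5-trimethoxyphenyl on the nitrogen gives an at least 2.3-fold higher number from compound 2 to compound 3 (0.37 log units; beyond the scatter) and an at least 4.2-fold higher number from compound 1 to compound 3 (0.62 log units; beyond the scatter). Both steps point towards weaker inhibition. Compound 3 gives a limit, not a number, so the full size of both steps stays unknown: the limit of > 50000 nM in this assay, at which 1 of the 3 values shown sits.

From the compounds shown here alone, whether a single methoxy group on the phenyl ring would produce the same step, or only all three together, remains open. So does how an amine or a carboxylic acid on this ring would read.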